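Swapping the aryl cap on compound 1 for an acetamide chain

A few compounds are considered here, and "the series" means these few. Any claim that something is new, unique, unknown or untested is made for them only; others in the source may bear on it.

Compound 1 `CCOC(=O)C1=Cc2ccccc2OC1(OCc1cn(-c2ccc(F)cc2)nn1)C(F)(F)F` gives 8900 nM in a functional assay on DU-145 cells (Homo sapiens) for inhibition, read by MTT assay, with a stated time of 24 h; on this read-out higher numbers stand for weaker inhibition and lower numbers for stronger inhibition.
Compound 2 `CCOC(=O)C1=Cc2ccccc2OC1(OCc1cc(-c2ccc([N+](=O)[O-])cc2)no1)C(F)(F)F` gives > 150000 nM in this assay, which is a limit of the assay rather than a number.
Compound 3 `O=C(O)C1=Cc2ccccc2OC1(OCc1cc(-c2ccc(F)cc2)no1)C(F)(F)F` gives 168000 nM in this assay.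

Going by the values given here, only two of these three readings are numbers. Among them compound 1 holds the lower one, and compound 3 stands clearly higher, a gap that lies beyond the scatter of repeated measurements. Compound 2 reaches only a limit of the assay and cannot be ranked against the others.

The step from compound 1 leads to compound 4 `CCOC(=O)C1=Cc2ccccc2OC1(OCc1cn(CC(=O)Nc2ccc(I)cc2Cl)nn1)C(F)(F)F`, which has not yet been measured in this assay. The change sits on the five-membered aromatic ring with 3 nitrogen:

((2-chloro-4-iodophenyl)carbamoyl)methyl in place of 4-fluorophenyl on an aromatic nitrogen

The remainder of the shared core, including the trifluoromethyl group and the ethyl ester, is unchanged. Among the compounds with values here, none of the measured pairs differ in just one place, so no measured step tells what this swap should do. A modest weakening is expected, and the step from compound 1 to compound 4 is estimated at a 1.7-fold higher number from compound 1 to compound 4 (0.23 log units; within the scatter), with the wide range reflecting how little is known about this position.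

Compound 4 is therefore expected to give about 15000 nM, within a range from 4000 nM to 60000 nM.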

Compound 4, half-maximal inhibitory concentration: 24400 nM
Estimate against measurement, compound 4: 1.6-fold (0.21 log units) below, and the stated range covers the measured number.
By their numbers in this assay, from the lowest: compound 1; then compound 4; then compound 3.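

In this assay, going by these compounds alone, the only measured step at this position, on the aromatic nitrogen of the five-membered ring, shows that ((2-chloro-4-iodophenyl)carbamoyl)methyl in place of 4-fluorophenyl gives a 2.7-fold higher number from compound 1 to compound 4 (0.44 log units; beyond the scatter). The change is real but modest: the larger group, which brings an amide and no longer attaches its aromatic ring directly to that nitrogen, weakens inhibition without abolishing it, so this position accepts a substantial change in the attached group. Nothing measured in this set explains why the number rises.

The compounds shown leave open whether the weakening belongs to the acetamide chain itself or to the chlorine and iodine on its ring, and a plain phenyl or a 4-fluorophenyl carried on the same chain would separate those two parts of the change. Going by these compounds, it also remains open how this position would respond to a group with no aromatic ring at all, such as an amine or a carboxylic acid at the end of a longer chain.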